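The compounds below may be only part of what the source reports. "The series", "measured", "known", "first", "only" and "open" are said of these compounds alone.

Measured so far in a functional assay on VCaP cells (Homo sapiens) for antiproliferative activity, read by propidium iodide staining, with a stated time of 96 h; on this read-out higher numbers stand for weaker inhibition and lower numbers for stronger inhibition:

Compound 1 `CC(O)(CSc1ccccc1C(F)(F)F)C(=O)Nc1ccc(S(F)(F)(F)(F)F)cc1`: 21000 nM
Compound 2 `CC(O)(CSc1ccccc1OC(F)(F)F)C(=O)Nc1ccc(S(F)(F)(F)(F)F)cc1`: 10100 nM
Compound 3 `CC(O)(CSc1ccc(C(F)(F)F)cc1)C(=O)Nc1cccc(S(F)(F)(F)(F)F)c1`: 27300 nM

Compound 1 and compound 2 differ in one place, (trifluoromethoxy in place of trifluoromethyl on an aromatic carbon), and that change gave a 2.1-fold lower number from compound 1 to compound 2 (0.32 log units; beyond the scatter). Compound 3 is built from the same atoms as compound 1, joined differently; the difference between the two cores is not broken down here. Compound 4 `CC(O)(CSc1ccc(OC(F)(F)F)cc1)C(=O)Nc1cccc(S(F)(F)(F)(F)F)c1` differs from compound 3 by trifluoromethoxy in place of trifluoromethyl on an aromatic carbon. The surroundings are not identical: in compound 1 the group sits ortho to a large group, in compound 3 para to a large group, so this is the same kind of change rather than the same change. Within the data shown here, the step from compound 3 to compound 4 is expected to be a 2.1-fold lower number from compound 3 to compound 4 (0.32 log units; beyond the scatter), resting on the earlier step of a 2.1-fold lower number from compound 1 to compound 2 (0.32 log units; beyond the scatter), and with only one precedent the expectation is loose. For compound 4 the expected value in this assay is 13000 nM, between 5000 nM and 35000 nM.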

Compound 4, half-maximal inhibitory concentration: 28500 nM
Compound 4: middle estimate off by 2.2-fold (0.34 log units), on the low side; the range from low to high includes it.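

In this assay, putting trifluoromethoxy in place of trifluoromethyl on the core of compound 3 gave a 1.0-fold higher number from compound 3 to compound 4 (0.02 log units; within the scatter), so on this core the change had no measurable effect. Set beside the earlier step, this result does not establish that the two cores respond differently: the same change on two cores in this assay, a 2.1-fold lower number (0.32 log units; beyond the scatter) from compound 1 to compound 2 and a 1.0-fold higher number (0.02 log units; within the scatter) from compound 3 to compound 4, 2.2-fold (0.34 log units) apart, within the scatter of two such steps. Among these compounds, with only two pairs, the data neither show that the change carries reliably from one core to another nor explain why its step was beyond the scatter on one core and within it on the other.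

The compounds shown leave open how this change behaves on further cores. They also leave open what a nitrile or a carboxylic acid would do in place of these fluorinated groups.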